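Notes on the series: compound 3 to compound 4

The source may report more compounds than this note shows. Statements on the series, on what has been measured and on what is new or still open speak of the compounds shown alone.

Three compounds on the shared core have entries in an ADME assay on a cell-free system (plasma, Rattus norvegicus) for metabolic stability, read by LC-MS, with a stated time of 1 h, at 37 degrees C, tested at 100 uM; a higher number here means that more of the compound is left, a lower number that less of the compound is left. For compound 1 `O=C1c2ccc(OCc3cccc(-c4ccc(Cl)cc4F)c3)cc2CN1C1CCCC1` the entry is "not determined" (no result reported). Among the measured compounds shown here, for compound 2 `O=C1c2ccc(OCc3cccc(-c4ccccc4)c3)cc2CN1C1CCCC1` the entry is 95%, the only number so far. For compound 3 `O=C1c2ccc(OCc3cccc(-c4ccc(C(F)(F)F)cc4F)c3)cc2CN1C1CCCC1` the entry is "not determined" (no result reported). For the measured compounds named here, compound 3 therefore has no place on the numerical scale, and no step between measured compounds can be read.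

Compound 4 `O=C(O)c1cc(F)cc(-c2cccc(COc3ccc4c(c3)CN(C3CCCC3)C4=O)c2)c1` departs from compound 3 at one place, on an aromatic carbon of a six-membered aromatic ring of carbon only, meta to a large group. There, 3-carboxy-5-fluorophenyl stands in place of 2-fluoro-4-(trifluoromethyl)phenyl (3-carboxy-5-fluorophenyl in place of 2-fluoro-4-(trifluoromethyl)phenyl on an aromatic carbon).

Going by the values given here, no measured compound carries the entering group, so the data give no direct guide to its effect. Among the compounds with values here, the only anchor is compound 2 at 95%, which shares the core but carries neither group. Against that anchor, no step beyond the usual scatter is expected in this assay, though any departure is more likely to be downward given how high the anchor sits. For compound 4 the estimated value is 92%, with an expected range of 78% to 103%.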

Compound 4, percent of the compound remaining: 95%
The estimate for compound 4 lay 3 percentage points below the measured number; the measured number falls inside the stated range.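

In this assay, among the compounds shown here, there is no change at the digits printed from compound 2 to compound 4 (within the scatter), the first step that can be read at this position, an aromatic carbon meta to a large group. For the compounds shown here, the change is 3-carboxy-5-fluorophenyl in place of phenyl, so a ring carrying a carboxylic acid and a fluorine sits at this place with the read-out unchanged, whereas the earlier compounds gave a single number for phenyl alone and none for a substituted ring. Steps involving compound 1 or compound 3 cannot be read, and nothing available here bears on why the read-out stays flat.

The compounds shown leave open how the carboxylic acid and the fluorine each count on their own, as no compound here carries one on the ring without the other. Also open, on these data alone, is whether a ring with an amine, a nitrile or a primary amide at this place, or a carboxylic acid set on a longer chain, would stay as level with compound 2 as compound 4 does.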